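Swapping Trifluoromethyl for Methoxy in a Growth Inhibitor

This account rests on a few compounds, and the source may have more. Where it says the series, first, only, none or still open, it means among the compounds named here.

In a functional assay on MCF7 cells (Homo sapiens) for inhibition, read by CCK-8 assay, with a stated time of 48 h (a lower number here means a stronger inhibitor of growth, a higher number a weaker inhibitor of growth), compound 1 (`Cc1ccccc1Nc1nc(Nc2ccc(N3CCNCC3)cn2)ncc1Cl`) gives 3410 nM, while compound 2 (`CN1CCN(c2ccc(Nc3ncc(Cl)c(NCc4ccc(C(F)(F)F)cc4)n3)nc2)CC1`) gives 28400 nM. Compound 2 therefore has the higher of the two numbers, and the gap lies beyond the usual scatter. Compound 3 (`COc1ccc(CNc2nc(Nc3ccc(N4CCN(C)CC4)cn3)ncc2Cl)cc1`) has methoxy in place of trifluoromethyl on an aromatic carbon, para to a large group (methoxy in place of trifluoromethyl on an aromatic carbon). Among the measured compounds shown here, no measured pair shows this change alone, so the expectation is tentative. The expected 2.4-fold lower number from compound 2 to compound 3 (0.37 log units; beyond the scatter) is a modest fall in this assay, slightly beyond the scatter. For compound 3 the estimated value is 12000 nM, within an expected range of 4500 nM to 32000 nM.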

Compound 3, concentration for 50% growth inhibition: 17300 nM
Estimate against measurement, compound 3: 1.4-fold (0.16 log units) below, and the stated range covers the measured number.
By their numbers in this assay, from the lowest: compound 1; then compounds 3 and 2 (each within the scatter of the next).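

In this assay, replacing 4-(trifluoromethyl)benzyl with 4-methoxybenzyl gives a 1.6-fold lower number from compound 2 to compound 3 (0.22 log units; within the scatter), so at this position the two groups cannot be told apart. Among the compounds shown here, this is the first pair here that differs in one place, and it isolates a change that compound 1 and compound 2 could not show. No measured data explain this result. From the compounds shown here alone, whether an amine or a carboxylic acid at this aromatic carbon would give a number beyond the scatter remains open. So does whether a longer chain in place of methoxy would do so.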